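The source may report more compounds than this note shows. Statements on the series, on what has been measured and on what is new or still open speak of the compounds shown alone.

In a functional assay on SK-MEL-28 cells (Homo sapiens) for inhibition, read by MTT assay, with a stated time of 48 h (on this read-out higher numbers stand for weaker inhibition and lower numbers for stronger inhibition), compound 1 `C(=C/c1nc2ccccn2c1Sc1ccccc1)\c1ccccc1` gives 65400 nM and compound 2 `Clc1ccc2nc(-c3ccccc3)c(Sc3ccccc3)n2c1` gives 76900 nM so the two stand within the usual scatter of each other. Compound 3 `c1ccc(Sc2c(-c3ccsc3)nc3ccccn23)cc1` carries thiophen-3-yl in place of 2-phenylethenyl on an aromatic carbon, a change from compound 1 counted as thiophen-3-yl in place of 2-phenylethenyl on an aromatic carbon in full. Among the compounds with values here, no measured pair shows this change, so in this assay no step beyond the scatter is expected in either direction. The estimated step of a 1.3-fold lower number from compound 1 to compound 3 (0.12 log units; within the scatter) stays within that scatter. Compound 3 is estimated at 50000 nM with 15000 nM to 120000 nM as its expected range.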

Compound 3, half-maximal inhibitory concentration: 69300 nM
Beside the measured number, compound 3's estimate is 1.4-fold (0.14 log units) below it; measured number inside the range.
By their numbers in this assay, from the lowest: compounds 1, 3 and 2 (each within the scatter of the next).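

In this assay, thiophen-3-yl in place of 2-phenylethenyl on this aromatic carbon gives a 1.1-fold higher number from compound 1 to compound 3 (0.03 log units; within the scatter). The position thus accepts an exchange of a six-membered aromatic ring of carbon only and its double bond outside aromatic rings for a five-membered aromatic ring with sulfur, with no step beyond the scatter. Nothing measured here explains why the two groups read alike.

Still open, from the compounds shown here alone, is whether any group on this carbon moves the read-out beyond the scatter. An amine or a carboxylic acid there would test this, as neither group in this pair carries a hydrogen-bond donor.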